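A few compounds are considered here, and "the series" means these few. Any claim that something is new, unique, unknown or untested is made for them only; others in the source may bear on it.

Compound 1 `COc1ccc(/C=C/c2cc(OC)c(OC)c(OC)c2-c2ccc(F)c(F)c2)cc1`: 9200 nM
Compound 2 `C=C(c1ccc(OC)cc1)c1cc(OC)c(OC)c(OC)c1-c1ccc(OC)cc1`: 72000 nM
Compound 3 `C=C(c1ccc(OC)cc1)c1cc(OC)c(OC)c(OC)c1-c1ccc(F)c(F)c1`: 5900 nM

All values come from a functional assay on HeLa cells (Homo sapiens) for cytotoxicity, read by MTT assay, with a stated time of 48 h; on this read-out lower numbers stand for stronger inhibition and higher numbers for weaker inhibition. Compound 3 shares the low end of this small range with one other compound. The step of a 1.6-fold lower number from compound 1 to compound 3 (0.19 log units; within the scatter) gives no separation, whereas a 12-fold lower number from compound 2 to compound 3 (1.09 log units; beyond the scatter) is large.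

Next is compound 4 `C=C(c1ccc(OC)cc1)c1cc(OC)c(OC)c(OC)c1-c1ccccc1`, with phenyl in place of 3,4-difluorophenyl on an aromatic carbon. The step from compound 2 bears most directly, as it changes the same place, while the step from compound 1 concerns the other group. Phenyl matches neither 3,4-difluorophenyl nor 4-methoxyphenyl, so a moderate rise in this assay is expected, smaller than the step from compound 2 but probably beyond the scatter. The expected change is a 3.4-fold higher number from compound 3 to compound 4 (0.53 log units; beyond the scatter). Compound 4 is estimated at 20000 nM, within an expected range of 6000 nM to 70000 nM.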

Compound 4, half-maximal inhibitory concentration: 11000 nM
Estimate against measurement, compound 4: 1.8-fold (0.26 log units) above; the range from low to high includes it.
By their numbers in this assay, from the lowest: compounds 3, 1 and 4 (each within the scatter of the next); then compound 2.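

At this position, ortho to a 1-(4-methoxyphenyl)ethenyl group, phenyl and 3,4-difluorophenyl are not separated in this assay, with a 1.9-fold higher number from compound 3 to compound 4 (0.27 log units; within the scatter). Hydrogen in place of methoxy gives a 6.5-fold lower number from compound 2 to compound 4 (0.82 log units; beyond the scatter), so among these three groups 4-methoxyphenyl alone stands apart, and the fluorines are not needed to reach the level of compound 3. No measurement shown gives a reason for this difference. Open, as far as these compounds go, is whether an amine or a carboxylic acid on this phenyl ring would stay at the level of compound 4. Also open, from the compounds shown here alone, is whether phenyl behaves the same way alongside the 2-(4-methoxyphenyl)ethenyl group of compound 1.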